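The source may report more compounds than this note shows. Statements on the series, on what has been measured and on what is new or still open speak of the compounds shown alone.

Compound 1 `N#CC1=C(N)Oc2c(c3nc4ccccc4nc3c3ccccc23)C12C(=O)N(Cc1cnnn1-c1cccc(Cl)c1)c1ccccc12` and compound 2 `CCOc1ccc(-n2nncc2CN2C(=O)C3(C(C#N)=C(N)Oc4c3c3nc5ccccc5nc3c3ccccc43)c3ccccc32)cc1` share the same core and differ only at the group on an aromatic nitrogen. In a functional assay on HCT-116 cells (Homo sapiens) for antiproliferative activity, read by MTT assay, with a stated time of 48 h (a higher number here means a weaker inhibitor, a lower number a stronger inhibitor), compound 1 reaches only the limit of the assay, > 50000 nM. In this assay compound 2 likewise reaches only the limit, > 50000 nM. The step that the two limits leave unreadable from compound 1 to compound 2 therefore cannot be read in size because of the limit of > 50000 nM in this assay, at which 2 of the 2 values shown sit. Compound 3 `CC(=O)Nc1ccc(-n2nncc2CN2C(=O)C3(C(C#N)=C(N)Oc4c3c3nc5ccccc5nc3c3ccccc43)c3ccccc32)cc1` differs from compound 2 by acetamido in place of ethoxy on an aromatic carbon. Going by the values given here, no measured step gives a readable size, so compound 3 is expected to stay near the same limit, an expected step that the limit leaves unreadable from compound 2 to compound 3. The estimate for compound 3 is 60000 nM, between 20000 nM and 200000 nM.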

Compound 3, half-maximal inhibitory concentration: > 50000 nM
Compound 3: only a limit was reported; the forecaster's own chance of this, stated with the estimate: 80%; the middle value does not contradict the limit.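

Compound 3 gives only a limit, as do compound 1 and compound 2, so no step among these compounds can be read in size: the limit of > 50000 nM in this assay, at which 3 of the 3 values shown sit.

In this assay the compounds shown leave open which change, if any, would give a readable value.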